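Trimming the oxime ester side chain of compound 2

The source may report more compounds than this note shows. Statements on the series, on what has been measured and on what is new or still open speak of the compounds shown alone.

Compound 1 `COc1ccc(C(O)(Cc2ccc(C)cc2)c2cccc3ccccc23)c(OC)c1OC`: in a functional assay on MDA-MB-231 cells (Homo sapiens) for inhibition, read by sulforhodamine B assay, with a stated time of 48 h (a higher number here means a weaker inhibitor, a lower number a stronger inhibitor), compound 1 gives only a limit, > 20000 nM.
Compound 2 `CCOC(=O)CO/N=C(/c1ccc(OC)c(OC)c1OC)c1cccc2ccccc12`: in this assay compound 2 gives 16400 nM.
Compound 3 `CCOC(=O)C(C)C(O)(c1ccc(OC)c(OC)c1OC)c1cccc2ccccc12`: in this assay compound 3 gives only a limit, > 20000 nM.

Within the data shown here, compound 2 holds the only genuine number in this assay; the other two results are limits of the assay, where (the limit of > 20000 nM in this assay, at which 2 of the 3 values shown sit). Among the measured compounds shown here, the single measured step, a step that the two limits leave unreadable from compound 1 to compound 3, runs between those two limits and its size cannot be read.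

Compound 4 `COc1ccc(/C(=N/OC(C)=O)c2cccc3ccccc23)c(OC)c1OC` differs from compound 2 by acetyl in place of (ethoxycarbonyl)methyl on an oxygen. For the measured compounds named here, no measured step touches this position, and the one step measured elsewhere in the set is unreadable, so nothing in the data points in either direction. The expectation therefore rests on compound 2 alone, and compound 4 is expected to stay within the scatter of it, a step of a 1.1-fold lower number from compound 2 to compound 4 (0.04 log units; within the scatter). Compound 4 is thus estimated at 15000 nM, within a range from 5000 nM to 40000 nM, with a real chance that the assay again reports only a limit.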

Compound 4, half-maximal inhibitory concentration: 17000 nM
Compound 4: middle estimate off by 1.1-fold (0.05 log units), on the low side; the measured number falls inside the stated range.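

Replacing (ethoxycarbonyl)methyl with acetyl on the oxygen bound to the double-bonded nitrogen gives, in this assay, a 1.0-fold higher number from compound 2 to compound 4 (0.02 log units; within the scatter). Among these compounds, this is the first step in the set that can be read, and it shows that going from 6 heavy atoms to 3 on this oxygen, with one fewer hydrogen-bond acceptor, leaves the number within the scatter. Compound 4 also gives a real number, so it stands with compound 2 as a second readable point, while the other two results remain limits: the limit of > 20000 nM in this assay, at which 2 of the 4 values shown sit.

Going by these compounds, whether a different kind of group on this oxygen would shift the number stays open, for example a carboxylic acid, an amine or a longer chain. A single pair also cannot say whether this swap would behave the same way on another core.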